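Methoxy for bromo on the exocyclic alkene

The source may hold more compounds than are shown below. What is called first, only, known or untested is meant among the compounds shown, and "the series" means these compounds.

Compound 1 `O=C1O/C(=C\Cn2cc(-c3ccc(Br)cc3)nn2)C(OCc2ccccc2)=C1OCc1ccccc1` is reported in a functional assay on MCF7 cells (Homo sapiens) for antiproliferative activity, read by MTT assay, with a stated time of 72 h (on this read-out higher numbers stand for weaker inhibition and lower numbers for stronger inhibition), only as a limit, > 100000 nM. Compound 3 `CC(C)(C)OC(=O)N1CCN(C(=S)SCc2cn(C[C@H](O)[C@H]3OC(=O)C(OCc4ccccc4)=C3OCc3ccccc3)nn2)CC1` likewise gives only a limit, > 100000 nM. Among the measured compounds shown here, compound 2 `O=C1O[C@H]([C@@H](O)Cn2cc(-c3ccc(Br)cc3)nn2)C(OCc2ccccc2)=C1OCc1ccccc1` is the one member with a number, giving 5620 nM in this assay. Compound 1 therefore stands at the weak end of what is shown; no step between measured compounds is available, and the limit of > 100000 nM in this assay, at which 2 of the 3 values shown sit, is the only frame around it. Compound 4 `COc1ccc(-c2cn(C/C=C3\OC(=O)C(OCc4ccccc4)=C3OCc3ccccc3)nn2)cc1` differs from compound 1 by methoxy in place of bromo on an aromatic carbon. In this assay no change beyond the scatter is expected from this exchange. Compound 4 is estimated at 100000 nM, within 20000 nM to 400000 nM. The expected step is a number no higher from compound 1 to compound 4 (the limit leaves the size open), inside the scatter.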

Compound 4, half-maximal inhibitory concentration: 39100 nM
Estimate against measurement, compound 4: 2.6-fold (0.41 log units) above; low and high end bracket the measured number.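

In this assay, 4-bromophenyl to 4-methoxyphenyl gives an at least 2.5-fold lower number from compound 1 to compound 4 (0.40 log units; beyond the scatter), so this position on the aromatic ring responds to the exchange, and the core of compound 1 can carry a measurable number. The true size of the step stays unknown, since the value for compound 1 is only a limit: the limit of > 100000 nM in this assay, at which 2 of the 4 values shown sit.

From the compounds shown here alone, whether an amine, a carboxylic acid or a longer alkoxy chain at this position would shift the number further remains open. So does whether the same exchange would act alike on the core of compound 2.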